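Nitrile to Carboxylic Acid at the Chain End

The source may hold more compounds than are shown below. What is called first, only, known or untested is meant among the compounds shown, and "the series" means these compounds.

Compound 1, `COc1cccc(Sc2c(NS(=O)(=O)c3ccc(C(C)(C)C)cc3)noc2CCCC#N)c1`, gives 1300 nM in an assay on A7R5 cells for displacement of a labelled ligand from Endothelin-1 receptor (Rattus norvegicus); on this read-out higher numbers stand for weaker inhibition and lower numbers for stronger inhibition.
Compound 2, `COc1cccc(Sc2c(NS(=O)(=O)c3ccc(C(C)(C)C)cc3)noc2CCCCC=O)c1`, gives 1400 nM in this assay.
Compound 3, `COc1cccc(Sc2c(NS(=O)(=O)c3ccc(C(C)(C)C)cc3)noc2C)c1`, gives 530 nM in this assay.

Among the three measured compounds, compound 1 stands second highest in this assay. Compound 2 is nearest to it, the step being a 1.1-fold higher number from compound 1 to compound 2 (0.03 log units; within the scatter), and compound 3 is furthest, with a 2.5-fold lower number from compound 1 to compound 3 (0.39 log units; beyond the scatter). Compound 4, `COc1cccc(Sc2c(NS(=O)(=O)c3ccc(C(C)(C)C)cc3)noc2CCCC(=O)O)c1`, is still to be measured. It differs from compound 1 by carboxy in place of cyano on a saturated chain carbon, three bonds along the chain from an aromatic carbon. Two kinds of measured step bear on this change. The step of a 1.1-fold higher number from compound 1 to compound 2 (0.03 log units; within the scatter) exchanges the group at the end of the chain while keeping the chain itself, and it stays within the scatter. The steps of a 2.5-fold lower number from compound 1 to compound 3 (0.39 log units; beyond the scatter) and a 2.6-fold lower number from compound 2 to compound 3 (0.42 log units; beyond the scatter) remove the whole chain and lower the number modestly; compound 4 keeps the chain, so they do not argue for a gain. The expected outcome is therefore a step of no change at the digits printed from compound 1 to compound 4 (within the scatter), within the scatter. Compound 4 is estimated at 1300 nM, with a range from 500 nM to 3500 nM.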

Compound 4, half-maximal inhibitory concentration: 4300 nM
For compound 4 the middle estimate is 3.3-fold (0.52 log units) below the measured one; measured number outside the range, above it.
By their numbers in this assay, from the lowest: compound 3; then compounds 1 and 2 (each within the scatter of the next); then compound 4.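

In this assay the end of this chain proves not to be indifferent to the group it carries: the exchange of nitrile for carboxy gives a 3.3-fold higher number from compound 1 to compound 4 (0.52 log units; beyond the scatter) and the exchange of the aldehyde end for carboxy gives a 3.1-fold higher number from compound 2 to compound 4 (0.49 log units; beyond the scatter) while the earlier exchange at the chain end stayed within the scatter. Setting the chain with its carboxy end against compound 3, which lacks the chain, gives an 8.1-fold higher number from compound 3 to compound 4 (0.91 log units; beyond the scatter) and this is the largest step among the four compounds, leaving compound 4 with the highest number of them. Nothing among the data shown explains why the carboxy end raises the number.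

The compounds shown leave open whether a methyl ester or a primary amide at the chain end would read like the carboxylic acid or like the nitrile. They also leave open how an amine at that end, or a shorter or longer chain ending in carboxy, would read.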